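The source may hold more compounds than are shown below. What is called first, only, known or untested is meant among the compounds shown, and "the series" means these compounds.

Compound 1 `CCOC(=O)/C(C#N)=C/c1ccoc1` is the smallest of three compounds that share one core and differ only in the group on the oxygen next to the carbonyl group. In a functional assay on the whole organism (strain CD1) for inhibition, with Mus musculus as the target, with stated times of 15 min and 20 min, at a dose of 10 mg/kg by the subcutaneous route (a lower number here means less inhibition, a higher number more inhibition at the dose given (going by the name of the read-out)), compound 1 gives 55.9%, the lowest of the three numbers. Compound 2 `CC(C)CCOC(=O)/C(C#N)=C/c1ccoc1` gives 82.2%, and compound 3 `N#C/C(=C\c1ccoc1)C(=O)OC1CCCCC1` gives 91.2%. The steps are a number 26.3 percentage points higher from compound 1 to compound 2 (beyond the scatter) and a number 35.3 percentage points higher from compound 1 to compound 3 (beyond the scatter), while a number 9 percentage points higher from compound 2 to compound 3 (within the scatter). Among these three compounds a larger group on that oxygen has gone with a higher number.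

Compound 4 `CCNC(=O)/C(C#N)=C/c1ccoc1` differs from compound 1 elsewhere: ethylamino in place of ethoxy on a carbonyl carbon. The group keeps its size, but a hydrogen-bond donor enters where a hydrogen-bond acceptor leaves. Within the data shown here, none of the measured steps touches this position, so they give no direction for it; they only show that the group on that side matters. With no guide either way, the number for compound 4 is expected to stay close to compound 1 and its 55.9%. The step from compound 1 is therefore expected to be a number 5.9 percentage points lower from compound 1 to compound 4 (within the scatter). The estimate for compound 4 in this assay is 50%, expected to fall between 25% and 78%.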

Compound 4, a percentage reported as inhibition, in the whole organism at one dose (the size of the read-out at that dose, not a potency): 31%
The estimate for compound 4 lay 19 percentage points above the measured number; measured number inside the range.
By their numbers in this assay, from the lowest: compound 4; then compound 1; then compounds 2 and 3 (each within the scatter of the next).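

Among these compounds, until now only the group on the oxygen had changed, so this is the first test of the atom that links that group to the carbonyl carbon. In this assay, ethylamino in place of ethoxy on a carbonyl carbon gives a number 24.9 percentage points lower from compound 1 to compound 4 (beyond the scatter), so a change that leaves the heavy-atom count of the group as it was still moves the number beyond the scatter. No measurement at hand accounts for this fall.

The compounds shown leave open whether cyclohexylamino or isopentylamino on the carbonyl carbon would bring the same rise that cyclohexyl and isopentyl brought on the oxygen. Also open, as far as these compounds go, is whether a dimethylamino group in this place would follow ethylamino or ethoxy.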